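Changing the amide group on a shared core

A few compounds are considered here, and "the series" means these few. Any claim that something is new, unique, unknown or untested is made for them only; others in the source may bear on it.

Three compounds share one core and were tested in an assay on microsomes from liver for inhibition of 3-hydroxy-3-methylglutaryl-coenzyme A reductase (Rattus norvegicus); on this read-out higher numbers stand for weaker inhibition and lower numbers for stronger inhibition. Compound 1 `CC(C)c1c(C(=O)N2CCC[C@H](c3ccccc3)C2)nn(-c2ccc(F)cc2)c1CC[C@@H](O)C[C@@H](O)CC(=O)O` gives 2.1 nM, compound 2 `CC(C)c1c(C(=O)N2CCC[C@H](c3ccccc3)C2)nn(-c2ccc(F)cc2)c1OC[C@@H](O)C[C@@H](O)CC(=O)O` gives 4.8 nM, and compound 3 `COc1cccc(CNC(=O)c2nn(-c3ccc(F)cc3)c(OC[C@@H](O)C[C@@H](O)CC(=O)O)c2C(C)C)c1` gives 16 nM, the highest number of the three. Two single-change steps have been measured: a 2.3-fold higher number from compound 1 to compound 2 (0.36 log units; beyond the scatter) and a 3.3-fold higher number from compound 2 to compound 3 (0.52 log units; beyond the scatter). Compound 4 `CC(C)c1c(C(=O)N(C)[C@H](C)c2ccccc2)nn(-c2ccc(F)cc2)c1OC[C@@H](O)C[C@@H](O)CC(=O)O` differs from compound 3 in one place: methyl(1-phenylethyl)amino in place of (3-methoxybenzyl)amino on a carbonyl carbon. Going by the values given here, the step that bears on this is the one from compound 2 to compound 3, which also altered the group on the carbonyl carbon and raised the number modestly; the entering group, like the 3-phenylpiperidin-1-yl of compound 2, has no hydrogen-bond donor. Compound 4 is therefore expected to show a modest fall, a 2.0-fold lower number from compound 3 to compound 4 (0.30 log units; within the scatter), to an estimated 8 nM with a range from 3 nM to 25 nM.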

Compound 4, half-maximal inhibitory concentration: 21 nM
The estimate for compound 4 lay 2.6-fold (0.42 log units) below the measured number, within the range that was stated.
By their numbers in this assay, from the lowest: compound 1; then compound 2; then compounds 3 and 4 (each within the scatter of the next).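

In this assay there is a 1.3-fold higher number from compound 3 to compound 4 (0.12 log units; within the scatter), so exchanging (3-methoxybenzyl)amino for methyl(1-phenylethyl)amino, which has no hydrogen-bond donor, leaves the number unmoved within the scatter. Having no donor on this carbonyl carbon is thus not enough to match compound 2, as there is a 4.4-fold higher number from compound 2 to compound 4 (0.64 log units; beyond the scatter) even though 3-phenylpiperidin-1-yl also has none. Nothing measured here explains these numbers.

Going by these compounds, what remains open is how a smaller benzyl(methyl)amino group or a simple dimethylamino group would score here. The compounds shown also leave open whether the mirror-image 1-phenylethyl group would give a different number.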